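Swapping the cyclohexyl acid for a hydroxymethyl thiane dioxide

This account rests on a few compounds, and the source may have more. Where it says the series, first, only, none or still open, it means among the compounds named here.

Measured so far:
- compound 1, `C[C@]1(C(=O)O)CC[C@H](C(=O)N2CC[C@](c3ccc(C(F)(C(F)(F)F)C(F)(F)F)cc3)(S(=O)(=O)c3ccc(F)cc3)C2)CC1`: 97%
- compound 2, `O=C(N1CC[C@](c2ccc(C(F)(C(F)(F)F)C(F)(F)F)cc2)(S(=O)(=O)c2ccc(F)cc2)C1)C12CCC(C(=O)O)(CC1)OC2`: "not determined" (no result reported)

In an ADME assay on microsomes from liver (Homo sapiens) for metabolic stability, with a stated time of 10 min (on this read-out lower numbers stand for a less stable compound and higher numbers for a more stable compound), compound 1 gives 97%. For the measured compounds named here, it is the only number; in this assay compound 2 gives "not determined" (no result reported), so compound 1 cannot be placed against anything yet, and no step between measured compounds exists. On its own reading, compound 1 sits close to the top of what this assay can report.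

Compound 3, `O=C(N1CC[C@](c2ccc(C(F)(C(F)(F)F)C(F)(F)F)cc2)(S(=O)(=O)c2ccc(F)cc2)C1)C1(CO)CCS(=O)(=O)CC1`, keeps the shared core of compound 1 and changes one group on the carbonyl carbon whose other neighbours are the amide-type nitrogen in a ring: 4-(hydroxymethyl)-1,1-dioxothian-4-yl in place of 4-carboxy-4-methylcyclohexyl on a carbonyl carbon

Without any measured step to lean on, the expectation for this assay rests on compound 1 alone. Because compound 1 gives 97%, there is little room upward, so the estimated step from compound 1 to compound 3 is a number 9 percentage points lower from compound 1 to compound 3 (within the scatter), a small move that may well stay within the scatter. Compound 3 is therefore estimated at 88%, with a range from 65% to 100%.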

Compound 3, percent of the compound remaining: 75%
Compound 3: the middle estimate sits 13 percentage points above what was measured, and the stated range covers the measured number.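

In this assay, for the compounds shown here, the first readable step at this position is a number 22 percentage points lower from compound 1 to compound 3 (beyond the scatter), so the group on a carbonyl carbon whose other neighbours are the amide-type nitrogen in a ring does affect this read-out, with the shared core unchanged. The 4-(hydroxymethyl)-1,1-dioxothian-4-yl group is therefore not a neutral replacement for 4-carboxy-4-methylcyclohexyl, although compound 3 still gives 75%. This one step changes the ring, the carboxy group and the methyl group together, and no measurement available here links the drop to any one of these parts.

On these data alone, it remains open whether the step follows the ring with its hetero atom or the exchange of the carboxy group for hydroxymethyl, a question that a carboxylic acid on the 1,1-dioxothiane ring or a hydroxymethyl group on the carbon-only ring would help to separate. Also open, as far as these compounds go, is how a basic amine at the same ring carbon, in place of the hydroxymethyl group, would read in this assay.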